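The compounds below may be only part of what the source reports. "The series", "measured", "known", "first", "only" and "open" are said of these compounds alone.

Going by the values given here, in a functional assay on MT4 cells (Homo sapiens) for cytotoxicity (a lower number here means that less compound is tolerated, a higher number that more compound is tolerated), compound 3 `CCCCSc1nc(O)c(C)c(C(C)c2c(F)cccc2F)n1` gives 112000 nM, the only actual number so far. Compound 1 `CC(c1cc(O)nc(SC2CCCCC2)n1)c1c(F)cccc1F` reads > 200000 nM, which is a limit of the assay and not a number. Compound 2 `CCC(C)Sc1nc(O)c(C)c(C(C)c2c(F)cccc2F)n1` reads > 200000 nM, also a limit. Compound 4 `Cc1c(O)nc(SC2CCCCC2)nc1C(C)c1c(F)cccc1F` has cyclohexyl in place of butyl on a sulfur, the group that compound 1 also carries there. Among the compounds with values here, the one measured step at this sulfur is an at least 1.7-fold lower number from compound 2 to compound 3 (0.25 log units; that floor lies within the scatter). Going by that small step, a small move toward a higher number is expected in this assay, perhaps no larger than the scatter. The estimated size is a 1.6-fold higher number from compound 3 to compound 4 (0.21 log units; within the scatter). For compound 4 the expected value is 180000 nM, within an estimated range of 90000 nM to 350000 nM.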

Compound 4, half-maximal cytotoxic concentration: > 200000 nM
Compound 4 gave a limit, no number; the forecaster's own chance of this, stated with the estimate: 55%; middle value at least 1.1-fold (0.04 log units) away from the limit.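

Putting cyclohexyl in place of butyl on the sulfur gives, in this assay, an at least 1.7-fold higher number from compound 3 to compound 4 (0.25 log units; that floor lies within the scatter). Among the groups compared on this sulfur, only butyl in compound 3 yields an actual number, while sec-butyl in compound 2 and cyclohexyl in compound 4 both end at a limit. The steps to compound 4 from compound 1 and compound 2 cannot be read, because both ends of each are limits: the limit of > 200000 nM in this assay, at which 3 of the 4 values shown sit.

As far as these compounds go, how much compound the cells tolerate with compound 2 and compound 4 therefore stays unknown, and the two cannot be ranked. Also open, from the compounds shown here alone, is what a longer chain or an amine on this sulfur would give.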